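A few compounds are considered here, and "the series" means these few. Any claim that something is new, unique, unknown or untested is made for them only; others in the source may bear on it.

The measured compounds and their numbers in an ADME assay on MRC5 cells (Homo sapiens) for cytotoxicity, read by MTT assay, with a stated time of 24 h; on this read-out higher numbers stand for weaker inhibition and lower numbers for stronger inhibition:

Compound 1 `CCOC(=O)c1c(C)[nH]c(=O)c(C#N)c1-c1ccc(C)cc1` gives 438000 nM.
Compound 2 `CCOC(=O)c1c(C)[nH]c(=O)c(C#N)c1-c1ccc(F)cc1` gives 149000 nM.
Compound 3 `CCOC(=O)c1c(C)[nH]c(=O)c(C#N)c1-c1ccc(Br)cc1` gives 310000 nM.

Compound 3 sits close to compound 1, the step of a 1.4-fold lower number from compound 1 to compound 3 (0.15 log units; within the scatter) lying within the scatter, while its distance from compound 2, a 2.1-fold higher number from compound 2 to compound 3 (0.32 log units; beyond the scatter), lies beyond it. Among the three, only compound 2 is set apart from the others beyond the scatter, and even that step, a 2.9-fold lower number from compound 1 to compound 2 (0.47 log units; beyond the scatter), is modest.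

Compound 4 `CCOC(=O)c1c(C)[nH]c(=O)c(C#N)c1-c1ccco1` has not yet been measured in this assay. It differs from compound 3 in one place: furan-2-yl in place of 4-bromophenyl on an aromatic carbon. For the measured compounds named here, none of the measured steps bears directly on this change: each of them exchanges one group for another on the same six-membered aromatic ring of carbon only, and none swaps that ring for furan-2-yl. What they do show is the scale of change seen so far in this set: the largest, a 2.9-fold lower number from compound 1 to compound 2 (0.47 log units; beyond the scatter), is modest, and a 2.1-fold higher number from compound 2 to compound 3 (0.32 log units; beyond the scatter) and a 1.4-fold lower number from compound 1 to compound 3 (0.15 log units; within the scatter) are smaller still. Going by the values given here, with no step of the relevant kind in hand, the account expects for compound 4 a number near that of compound 3, with a step of a 1.0-fold lower number from compound 3 to compound 4 (0.01 log units; within the scatter) that may well fall within the scatter. The estimate for compound 4 in this assay is 300000 nM, with a range from 120000 nM to 750000 nM.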

Compound 4, half-maximal inhibitory concentration: 407000 nM
For compound 4 the middle estimate is 1.4-fold (0.13 log units) below the measured one, within the range that was stated.
By their numbers in this assay, from the lowest: compound 2; then compounds 3, 4 and 1 (each within the scatter of the next).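

In this assay, for the compounds shown here, replacing the six-membered aromatic ring of carbon only at this position, opposite the ring nitrogen, with furan-2-yl gives no shift that stands clear of the scatter against two of the earlier compounds: a 1.3-fold higher number from compound 3 to compound 4 (0.12 log units; within the scatter) and a 1.1-fold lower number from compound 1 to compound 4 (0.03 log units; within the scatter). Going by these compounds alone, a five-membered aromatic ring with one hetero atom is thus read here alike with the 4-bromophenyl and 4-methylphenyl groups, and the change of ring adds no larger distance to the set, with the only step beyond the scatter being the modest one to the 4-fluorophenyl compound, a 2.7-fold higher number from compound 2 to compound 4 (0.44 log units; beyond the scatter). Nothing given here accounts for why these groups read alike or why compound 2 stands apart.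

The compounds leave open whether a group on this carbon that is not an aromatic ring, such as an amine or a longer alkyl chain, would move the number further than these steps do. They also leave open whether a thiophene or pyridine ring in the same place would read like furan-2-yl, and whether a carboxylic acid in place of the ethoxycarbonyl group would change the picture.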